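A few compounds are considered here, and "the series" means these few. Any claim that something is new, unique, unknown or untested is made for them only; others in the source may bear on it.

Measured in an ADME assay on the whole organism (Mus musculus, strain C57BL/6) for pharmacokinetics, read by HPLC, with a stated time of 6 h, at a dose of 25 mg/kg by the oral route; a higher number here means more compound in the circulation at the dose given, a lower number less compound in the circulation:
- Compound 1 `O=C(O)[C@H](CO)NC(=O)[C@H]1C[C@H](O)CN1`: 4010 nM
- Compound 2 `O=C(O)[C@H](CO)NC(=O)[C@@H]1C[C@H](O)CN1`: 1050 nM

Compound 2 holds the lower of the two numbers. Among the compounds with values here, only one measured step bears on what follows: a 3.8-fold lower number from compound 1 to compound 2 (0.58 log units; beyond the scatter), which comes with the fact that compounds 1 and 2 differ only in the configuration as drawn. Compound 3 `O=C(N[C@H](CO)C(=O)O)[C@@H]1C[C@@H](O)CN1` changes configuration again: the two compounds have the same atoms and bonds and differ only in configuration as drawn: 2 of 3 stereo elements differ; a stereocentre at a saturated chain carbon is drawn S in compound 2 and R in compound 3; a stereocentre at a saturated ring carbon is drawn S in compound 2 and R in compound 3. Within the data shown here, one such step gives no direction for a change at two stereocentres, so no step clearly beyond the scatter is expected in this assay, though one of similar size remains possible. The expected result is a 1.4-fold higher number from compound 2 to compound 3 (0.15 log units; within the scatter). For compound 3 the estimate is 1500 nM, with an expected range from 400 nM to 5000 nM.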

Compound 3, maximal plasma concentration: 640 nM
For compound 3 the middle estimate is 2.3-fold (0.37 log units) above the measured one; measured number inside the range.
By their numbers in this assay, from the lowest: compounds 3 and 2 (each within the scatter of the next); then compound 1.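

Changing the chain stereocentre and one ring stereocentre together gives no clear separation in this assay: a 1.6-fold lower number from compound 2 to compound 3 (0.22 log units; within the scatter). Inverting all three stereocentres, which makes a mirror-image pair, gives a clear one: a 6.3-fold lower number from compound 1 to compound 3 (0.80 log units; beyond the scatter). Configuration alone thus accompanies this larger gap, with atoms and bonds unchanged: the fact that compounds 1 and 3 differ only in the configuration as drawn.

The compounds shown leave open what the chain stereocentre does on its own, since no pair shown differs there alone. They also leave open how the numbers would respond to a change of atoms, such as an ester in place of the carboxylic acid.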